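Trimethoxyphenyl series: replacing the indole with an aminomethoxyphenyl

The source may hold more compounds than are shown below. What is called first, only, known or untested is meant among the compounds shown, and "the series" means these compounds.

Of the compounds shown here, three have been tested in a functional assay on MCF7 cells (Homo sapiens) for inhibition, read by CCK-8 assay, with a stated time of 48 h; a lower number here means a stronger inhibitor, a higher number a weaker inhibitor. Compound 3, `COc1cc(-c2ccnc3cc(-c4ccc5c(ccn5C)c4)nn23)cc(OC)c1OC`, gives 3 nM and stands lowest of the three. Compound 1, `COc1cc(-c2ccnc3cc(-c4cn(CO)c5ccccc45)nn23)cc(OC)c1OC`, gives 19 nM in this assay, a gap beyond the scatter, and compound 2, `Cn1ccc2cc(-c3cc4nccc(-c5ccc(F)cc5)n4n3)ccc21`, which lacks the trimethoxyphenyl group, gives 4580 nM, by far the highest number. Compound 3 is thus the most potent of the three.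

Compound 4, `COc1ccc(-c2cc3nccc(-c4cc(OC)c(OC)c(OC)c4)n3n2)cc1N`, has not yet been measured. It keeps the trimethoxyphenyl group of compound 3 and differs in one place: 3-amino-4-methoxyphenyl in place of 1-methyl-1H-indol-5-yl on an aromatic carbon. Within the data shown here, no step between measured compounds involves this exact exchange, so the expectation rests on compound 3 alone and on the fact that the trimethoxyphenyl group, which compound 2 lacks, is retained.

Compound 4 is expected to remain a strong inhibitor, with a step of a 3.3-fold higher number from compound 3 to compound 4 (0.52 log units; beyond the scatter) that may amount to a modest weakening, possibly within the scatter. The estimate for compound 4 in this assay is 10 nM, with a range from 2 nM to 50 nM.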

Compound 4, half-maximal inhibitory concentration: 27 nM
Beside the measured number, compound 4's estimate is 2.7-fold (0.43 log units) below it, within the range that was stated.
By their numbers in this assay, from the lowest: compound 3; then compounds 1 and 4 (each within the scatter of the next); then compound 2.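

In this assay, the exchange on this aromatic carbon of the five-membered aromatic ring gives a 9.0-fold higher number from compound 3 to compound 4 (0.95 log units; beyond the scatter), so the two groups are not equivalent at this place. Even so, the fused 1-methyl-1H-indol-5-yl is not required for strong inhibition: with a single six-membered aromatic ring of carbon only, carrying amino and methoxy groups, compound 4 still gives 27 nM. No measurement at hand accounts for the size of this step.

This one step changes the ring system and both substituents together, leaving the separate contributions of the amine and the methoxy group unresolved. Also open, going by these compounds, is how a 3-hydroxy-4-methoxyphenyl group, with a hydroxyl in place of the amine, or a plain 4-methoxyphenyl group would read at this place.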